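Amino in Place of Methoxy on the Aryl Ketone

The source may report more compounds than this note shows. Statements on the series, on what has been measured and on what is new or still open speak of the compounds shown alone.

Compound 1 `O=C(/C=C/C1=Cc2ccccc2OC1)c1ccccc1F` gives 64.4% in a functional assay on the whole organism for inhibition, with Mus musculus as the target, with a stated time of 1 h, at a dose of 30 mg/kg by the intraperitoneal route; a higher number here means more inhibition at the dose given (going by the name of the read-out), a lower number less inhibition.
Compound 2 `O=C(/C=C/C1=Cc2ccccc2OC1)c1ccc(F)cc1` gives 65.6%.
Compound 3 `COc1ccc(C(=O)/C=C/C2=Cc3ccccc3OC2)cc1` gives 66.2%.

The three measured compounds share one core and differ only in the aryl group on the carbonyl carbon. Moving the fluoro from one position to another gave a number 1.2 percentage points higher from compound 1 to compound 2 (within the scatter), and exchanging fluoro for methoxy gave a number 0.6 percentage points higher from compound 2 to compound 3 (within the scatter). Compound 3 therefore stands within the scatter of compound 2 and of compound 1 alike; the three numbers cannot be told apart.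

Compound 4 `Nc1ccc(C(=O)/C=C/C2=Cc3ccccc3OC2)cc1` is not yet measured. It differs from compound 3 by amino in place of methoxy on an aromatic carbon. Among the measured compounds shown here, the step that bears most directly on this change is the one from compound 2 to compound 3, which also swapped the group at this aromatic carbon and stayed within the scatter; the step from compound 1 to compound 2 shows the same for a shift of position. Nothing in the measured data suggests that the aryl substituent moves the read-out beyond the scatter, so the expected step of a number 1.2 percentage points lower from compound 3 to compound 4 (within the scatter) is small. Compound 4 is estimated at 65%, with a range from 52% to 78%.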

Compound 4, a percentage reported as inhibition, in the whole organism at one dose (the size of the read-out at that dose, not a potency): 52.6%
For compound 4 the middle estimate is 12.4 percentage points above the measured one; the measured number falls inside the stated range.
By their numbers in this assay, from the lowest: compound 4; then compounds 1, 2 and 3 (each within the scatter of the next).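

In this assay, the aryl group on the carbonyl carbon proves able to move the read-out: amino in place of methoxy gave a number 13.6 percentage points lower from compound 3 to compound 4 (beyond the scatter), a step beyond the scatter, where the earlier changes at this group had all stayed within it. The other two comparisons agree, with amino in place of fluoro giving a number 13 percentage points lower from compound 2 to compound 4 (beyond the scatter) and 4-aminophenyl in place of 2-fluorophenyl giving a number 11.8 percentage points lower from compound 1 to compound 4 (beyond the scatter), so among these four compounds compound 4 alone stands apart, while the fluoro and methoxy compounds cannot be told apart. No measurement shown here speaks to the reason for this drop.

As far as these compounds go, it remains open whether the lower number belongs to the free amino group itself or to any nitrogen on this aromatic carbon; a dimethylamino or an acetamido group at the same place would separate the two, and a hydroxy group would show whether another group bearing a hydrogen-bond donor behaves alike. Also open is whether amino on another carbon of this aryl ring gives the same result, since the fluoro pair is the only change of position shown.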